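Permeability of a triazine acylsulfonamide series

The source may hold more compounds than are shown below. What is called first, only, known or untested is meant among the compounds shown, and "the series" means these compounds.

Measured so far:
Compound 1, `O=C(NS(=O)(=O)c1ccc(F)cc1)c1ccc(Nc2nc(NC3(c4ccc(Cl)cc4)CC3)nc(OCC(F)(F)F)n2)cc1`: 193 nm/s
Compound 2, `CC(C)(C)OC(=O)NCCS(=O)(=O)NC(=O)c1ccc(Nc2nc(NC3(c4ccc(Cl)cc4)CC3)nc(OCC(F)(F)F)n2)cc1`: 111 nm/s

Compound 1 and compound 2 share the same core and differ only in the group on the sulfonyl sulfur. In a physicochemical assay for permeability, using PAMPA, at pH 7.4 (a lower number here means that the compound crosses the layer more slowly, a higher number that the compound crosses the layer faster), compound 1 gives 193 nm/s, and compound 2 gives 111 nm/s. Compound 2 holds the lowest of the two numbers, but the step of a 1.7-fold lower number from compound 1 to compound 2 (0.24 log units; within the scatter) lies within the scatter, so the two values cannot be told apart.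

Compound 3, `O=C(NS(=O)(=O)CCNCc1ccccc1)c1ccc(Nc2nc(NC3(c4ccc(Cl)cc4)CC3)nc(OCC(F)(F)F)n2)cc1`, has not yet been measured in this assay. It differs from compound 2 in that (benzyl in place of tert-butoxycarbonyl on an amine nitrogen). For the measured compounds named here, no measured step covers this particular change: the one step in hand, from compound 1 to compound 2, concerns a different part of the sulfonyl substituent and was within the scatter, so it offers no direct guide. The available comparison gives no firm basis for a direction, and the expectation therefore rests mainly on uncertainty. Compound 3 is estimated at 40 nm/s, with a range from 8 nm/s to 150 nm/s, and the expected step is a 2.8-fold lower number from compound 2 to compound 3 (0.44 log units; beyond the scatter).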

Compound 3, apparent permeability: 49 nm/s
For compound 3 the middle estimate is 1.2-fold (0.09 log units) below the measured one, within the range that was stated.
By their numbers in this assay, from the lowest: compound 3; then compounds 2 and 1 (each within the scatter of the next).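

In this assay, for the compounds shown here, benzyl in place of tert-butoxycarbonyl on the amine nitrogen gives a 2.3-fold lower number from compound 2 to compound 3 (0.36 log units; beyond the scatter), the first step here to lie beyond the scatter, so a change at this far end of the sulfonyl substituent can be read in this assay, even though the step from compound 1 to compound 2 could not. The heavy-atom count stays the same in this change, while an aromatic ring enters and the two hydrogen-bond acceptors of tert-butoxycarbonyl leave, and 2-(benzylamino)ethyl in place of 4-fluorophenyl on the sulfonyl sulfur gives a 3.9-fold lower number from compound 1 to compound 3 (0.60 log units; beyond the scatter), which sets compound 3 apart from both earlier compounds. No measurement at hand bears on why the number moves with this change.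

The compounds shown leave open whether the step goes with the aromatic ring that enters or with the tert-butoxycarbonyl group that leaves, since both happen in the same change. A cyclohexylmethyl group or an acetyl group on that nitrogen, the free amine, or a longer chain to the sulfonyl sulfur would each bear on that question.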